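A few compounds are considered here, and "the series" means these few. Any claim that something is new, unique, unknown or untested is made for them only; others in the source may bear on it.

Compound 2 `CCCN(CCC)c1cc2[nH]c(C3CCCCC3)nc2cc1NC(=O)c1ccccc1` and compound 1 `CCN(CC)c1cc2[nH]c(C3CCCCC3)nc2cc1NC(=O)c1cnccn1` share the same core and differ in the two groups on the amine nitrogen and in the amide group. In an ADME assay on Vero cells (Chlorocebus sabaeus) for cytotoxicity, read by resazurin assay, with a stated time of 3 days (a lower number here means a stronger inhibitor, a higher number a weaker inhibitor), compound 1 reaches only a limit of the assay, > 100 ug/mL. In this assay compound 2 likewise gives only a limit, > 100 ug/mL. Both results sit at the limit of > 100 ug/mL in this assay, at which 2 of the 2 values shown sit, so compound 2 stands at the edge of what this assay reports, with no number that would place it against compound 1. Compound 3 `CCCN(CCC)c1cc2[nH]c(C3CCCCC3)nc2cc1NC(=O)OCc1ccccc1` follows from compound 2 by one change: benzyloxy in place of phenyl on a carbonyl carbon. Going by the values given here, no measured step between two compounds of this kind is available, so the size of its effect is unknown. The expectation is that the step from compound 2 to compound 3 is none beyond the scatter, a number no higher from compound 2 to compound 3 (the limit leaves the size open). Compound 3 is therefore expected to give 100 ug/mL, within 50 ug/mL to 200 ug/mL.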

Compound 3, half-maximal inhibitory concentration: > 100 ug/mL
Compound 3 was reported as a limit; the forecaster's own chance of this, stated with the estimate: 80%; the middle value sits exactly at the limit.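

In this assay compound 3 gives only a limit, > 100 ug/mL. Going by these compounds alone, compound 2 also gives only a limit, so no step from compound 2 to compound 3 can be read. The compounds shown leave open where each one's true value lies, and whether they differ at all: the limit of > 100 ug/mL in this assay, at which 3 of the 3 values shown sit.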